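The source may hold more compounds than are shown below. What is called first, only, known or untested is meant among the compounds shown, and "the series" means these compounds.

Working notes on the series.

Compound 1 `COC(=O)C1=C(C)N=C(C)/C(=C(/O)OC)C1c1ccccc1OCCO[N+](=O)[O-]` sets the reference point: in an assay on Cortex for displacement of a labelled ligand from Voltage-dependent L-type calcium channel subunit alpha-1D (Rattus norvegicus) (on this read-out higher numbers stand for weaker inhibition and lower numbers for stronger inhibition), compound 1 gives 85 nM. Compound 2 `COC(=O)C1=C(C)N=C(C)/C(=C(/O)OC)C1c1cccc(OCCO[N+](=O)[O-])c1` carries the same 2-(nitrooxy)ethoxy group on a different part of the aryl ring and gives the higher of the two numbers; in this assay compound 2 gives 970 nM, and the gap to compound 1 lies beyond the scatter, so the placement of this side chain on the aryl ring matters on this read-out.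

Compound 3 `COC(=O)C1=C(C)N=C(C)/C(=C(/O)OC)C1c1cccc(OCc2nonc2C)c1` has not yet been measured. Relative to compound 2 the change is 4-methyl-1,2,5-oxadiazol-3-yl in place of (nitrooxy)methyl on a saturated chain carbon bound to an oxygen on an aromatic ring. Among the compounds with values here, no pair among the measured compounds shows this exchange, so the size and direction of the step have no precedent; only the values of compound 1 and compound 2 are known, and those differ in ring placement, not in the chain. With the group retained on the same part of the ring as in compound 2, a step of no more than the usual scatter is expected, with the direction open; the estimated step is a 1.2-fold lower number from compound 2 to compound 3 (0.08 log units; within the scatter). For compound 3 the expected result in this assay is 800 nM, with a range from 250 nM to 2600 nM.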

Compound 3, half-maximal inhibitory concentration: 720 nM
Beside the measured number, compound 3's estimate is 1.1-fold (0.05 log units) above it; the range from low to high includes it.
By their numbers in this assay, from the lowest: compound 1; then compounds 3 and 2 (each within the scatter of the next).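

The step within the chain now has a reading of its own, whereas the earlier pair spoke only to where the side chain sits on the aryl ring. In this assay the exchange of (nitrooxy)methyl for 4-methyl-1,2,5-oxadiazol-3-yl, on a saturated chain carbon bound to an oxygen on an aromatic ring, gives a 1.3-fold lower number from compound 2 to compound 3 (0.13 log units; within the scatter) and leaves compound 2 and compound 3 indistinguishable on this read-out, so at this place on the ring the nitrooxy group is not needed to keep the number at this level, and a five-membered aromatic ring with 3 hetero atoms serves in its stead. Nothing at hand bears on why the two groups read alike.

Open, as far as these compounds go, is whether the exchange would also leave the number unmoved with the side chain placed on the aryl ring as in compound 1, where the reference value is far lower and a step could turn out differently. Also open, from the compounds shown here alone, is how far this place accepts other groups, such as a primary amine, a carboxylic acid or a longer chain, in place of the (4-methyl-1,2,5-oxadiazol-3-yl)methoxy group.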